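The source may report more compounds than this note shows. Statements on the series, on what has been measured and on what is new or still open speak of the compounds shown alone.

Measured so far:
compound 1, `CN1CCN(c2ccc(-c3cc(=O)c4c(O)c(O)c(O)cc4o3)cc2)CC1`: > 100000 nM
compound 2, `Oc1cc2oc(-c3ccccc3)cc(=S)c2c(O)c1O`: > 100000 nM

In a toxicity assay on Huh-7 cells (Homo sapiens) for cytotoxicity, read by CCK-8 assay, with a stated time of 24 h (a lower number here means that less compound is tolerated, a higher number that more compound is tolerated), compound 1 gives only a limit, > 100000 nM. Compound 2 likewise returns only a limit, > 100000 nM. Compound 1 thus stands at the limit of > 100000 nM in this assay, at which 2 of the 2 values shown sit, and no number separates it from compound 2. Compound 3, `O=c1cc(-c2ccc(Nc3ccc(Cl)cc3)cc2)oc2cc(O)c(O)c(O)c12`, carries (4-chlorophenyl)amino in place of 4-methylpiperazin-1-yl on an aromatic carbon. Going by the values given here, no measured pair shows how such a change moves this assay. The account therefore expects little movement, a number no higher from compound 1 to compound 3 (the limit leaves the size open), nothing beyond the usual scatter. Compound 3 is estimated at 100000 nM, between 40000 nM and 250000 nM, and most probably it too will come back only as a limit.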

Compound 3, half-maximal cytotoxic concentration: > 100000 nM
Compound 3: only a limit was reported; the forecaster's own chance of this, stated with the estimate: 75%; the middle value lies on the limit itself.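

Compound 3, like compound 1, returns only a limit in this assay, so no step can be read between them: the limit of > 100000 nM in this assay, at which 3 of the 3 values shown sit. On these data alone, whether compound 1, compound 2 and compound 3 differ at all in this assay stays open.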